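The source may report more compounds than this note shows. Statements on the series, on what has been measured and on what is new or still open speak of the compounds shown alone.

Compound 1 `CCCSc1nnc(Cc2ccc(Cl)cc2Oc2ccccc2Cl)[nH]1` gives 118%
Compound 2 `CCCSc1nnc(Cc2ccc(Cl)cc2Oc2ccccc2F)[nH]1` gives 119%
Compound 3 `Nc1nnc(Cc2ccc(Cl)cc2Oc2ccccc2Cl)o1` gives 125%

All three numbers come from a functional assay on the whole organism (strain NMRI) with Mus musculus as the target, with a stated time of 60 min, at a dose of 5 mg/kg by the intraperitoneal route; a lower number here means a weaker effect, a higher number a stronger effect of the compound at the dose given. Compound 1 and compound 2 share a core and differ only by fluoro in place of chloro on an aromatic carbon; that change gave a number 1 percentage points higher from compound 1 to compound 2 (within the scatter). Compound 3 has a different core, and the difference between the two cores is not broken down here. In this assay compound 3 and compound 2 lie within the scatter of each other, as do compound 3 and compound 1.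

Compound 4 `Nc1nnc(Cc2ccc(Cl)cc2Oc2ccccc2F)o1` has not yet been measured. It differs from compound 3 by fluoro in place of chloro on an aromatic carbon, the same change that leads from compound 1 to compound 2. The step from compound 3 to compound 4 is expected to be no change at the digits printed from compound 3 to compound 4 (within the scatter), because a number 1 percentage points higher from compound 1 to compound 2 (within the scatter) stayed within the scatter. For compound 4 the estimate is 125%, expected to fall between 110% and 140%.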

Compound 4, a percentage reported as activity, at one dose (the size of the read-out at that dose, not a potency): 112%
For compound 4 the middle estimate is 13 percentage points above the measured one; low and high end bracket the measured number.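

On the core of compound 3, going from 2-chlorophenyl to 2-fluorophenyl gave a number 13 percentage points lower from compound 3 to compound 4 (beyond the scatter) in this assay, whereas on the core of compound 1 the same change stayed within the scatter. Set side by side, the two steps do not differ by more than repeated measurements would allow: the same change on two cores in this assay, a number 1 percentage points higher (within the scatter) from compound 1 to compound 2 and a number 13 percentage points lower (beyond the scatter) from compound 3 to compound 4, 14 percentage points apart, within the scatter of two such steps This gives no firm sign that the change behaves differently on the two cores, but two pairs cannot show that it carries over unchanged either.

The compounds shown leave open what a bromo or a methoxy group at the same place on the ring would do. They also leave open whether both cores would respond alike to such a group.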